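A few compounds are considered here, and "the series" means these few. Any claim that something is new, unique, unknown or untested is made for them only; others in the source may bear on it.

In a functional assay on KB cells (Homo sapiens) for antiproliferative activity, read by sulforhodamine B assay, with a stated time of 3 days (on this read-out lower numbers stand for an effect already at smaller amounts and higher numbers for an effect only at larger amounts of compound), compound 2 `CCOc1ccc(-c2cc(=O)c3c(o2)C(CC)(CC)C(=O)C(CC)=C3O)cc1` stands at > 52.4 uM. That value is a limit of the assay and not a number. For the measured compounds named here, the only other measured compound is compound 1 `CCC1=C(O)c2c(oc(-c3ccc(CC(C)C)cc3)cc2=O)C(CC)(CC)C1=O`, which gives 29.3 uM in this assay.

Compound 3 `CCCOc1ccc(-c2cc(=O)c3c(o2)C(CC)(CC)C(=O)C(CC)=C3O)cc1` turns the ethoxy of compound 2 into propoxy, with methyl in place of hydrogen on a saturated chain carbon, two bonds along the chain from an oxygen on an aromatic ring. Going by the values given here, the one measured step with any bearing on this is an at least 1.7-fold higher number from compound 1 to compound 2 (0.25 log units; that floor lies within the scatter). Among the compounds with values here, that step exchanges isobutyl for ethoxy on an aromatic carbon, so it concerns the same substituent but a different change, and no measured step covers a lengthening of the ethoxy chain. On this evidence, no step beyond the scatter is expected in this assay, and no direction is favoured. The expected step is an at least 1.0-fold lower number from compound 2 to compound 3 (0.02 log units; that floor lies within the scatter). A result reported only as a limit would not be surprising. The estimated value for compound 3 is 50 uM, within an expected range of 22 uM to 110 uM.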

Compound 3, concentration for half-maximal effect: > 50.5 uM
Compound 3: no number, only a limit; the forecaster's own chance of this, stated with the estimate: 50%; middle value at least 1.0-fold (0.00 log units) from the limit.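

In this assay, like compound 2, compound 3 gives > 50.5 uM, which is a limit of the assay and not a number. The step for methyl in place of hydrogen on a saturated chain carbon, two bonds along the chain from an oxygen on an aromatic ring, cannot be read, so going from ethoxy to propoxy yields no size or direction at this position. The exchange of isobutyl for propoxy on an aromatic carbon gives an at least 1.7-fold higher number from compound 1 to compound 3 (0.23 log units; that floor lies within the scatter), so the propoxy compound, like the ethoxy compound before it, is not separated from the isobutyl compound by more than the usual scatter.

Going by these compounds, whether any alkoxy group at this place gives a number rather than a limit in this assay remains open. A longer chain such as butoxy, or an amine in place of the propoxy group, would test whether this position can move the read-out at all.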